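The source may report more compounds than this note shows. Statements on the series, on what has been measured and on what is new or still open speak of the compounds shown alone.

Compound 1 `O=C(N/N=C\c1cn(Cc2ccc(Cl)cc2)c2cc(F)ccc12)c1c[nH]c2ccccc12` stands highest of the two numbers in hand: in a functional assay on LNCaP cells (Homo sapiens) for cytotoxicity (a higher number here means a weaker inhibitor, a lower number a stronger inhibitor), compound 1 gives 55200 nM. Compound 2 `O=C(N/N=C\c1cn(Cc2ccc(Cl)cc2)c2cc(F)ccc12)c1c[nH]c2ccc(Br)cc12` in this assay gives 24800 nM, reached by a 2.2-fold lower number from compound 1 to compound 2 (0.35 log units; beyond the scatter). Compound 3 `O=C(N/N=C\c1cn(Cc2ccc(Cl)cc2)c2ccccc12)c1c[nH]c2ccccc12` differs from compound 1 by hydrogen in place of fluoro on an aromatic carbon. Among the compounds with values here, no measured step touches this change; the only step known, from compound 1 to compound 2, alters a different place and is modest, so it offers no direct guide. A step of a 1.3-fold higher number from compound 1 to compound 3 (0.10 log units; within the scatter) is therefore expected, with no movement beyond the scatter. Compound 3 is estimated at 70000 nM, range 30000 nM to 160000 nM.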

Compound 3, half-maximal inhibitory concentration: > 100000 nM
Compound 3 gave a limit, no number (the forecaster's own chance of this, stated with the estimate: 20%); middle value at least 1.4-fold (0.15 log units) away from the limit.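

The change from fluoro to hydrogen, on an aromatic carbon meta to a fused ring and para to a fused ring, gives an at least 1.8-fold higher number from compound 1 to compound 3 (0.25 log units; that floor lies within the scatter). For compound 3 the reading in this assay is a limit, not a number: the limit of > 100000 nM in this assay, at which 1 of the 3 values shown sits. The floor of the step lies within the scatter, so hydrogen here shows no gain over fluoro, but a real loss is not established.

Going by these compounds, the full size of the step stays open. So does whether a chloro, a methoxy or an amine at this carbon would lower the number.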